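The compounds below may be only part of what the source reports. "The series", "measured", "known", "first", "only" and "open" are said of these compounds alone.

Compounds measured in a functional assay on HeLa cells (Homo sapiens) for antiproliferative activity, read by CCK-8 assay, with a stated time of 72 h; on this read-out lower numbers stand for stronger inhibition and higher numbers for weaker inhibition:
- compound 1 `O=C(Nc1cccc(-c2oc3cc(-c4ccc(F)cc4)ccc3c(=O)c2O)c1)c1ccc(F)cc1`: 5350 nM
- compound 2 `COc1ccc(C(=O)Nc2cccc(-c3oc4cc(-c5ccc(F)cc5)ccc4c(=O)c3O)c2)cc1`: 4820 nM
- compound 3 `COc1ccccc1C(=O)Nc1cccc(-c2oc3cc(-c4ccc(F)cc4)ccc3c(=O)c2O)c1`: 14100 nM

Compound 3 gives the highest number of the three; the nearest is compound 1, a 2.6-fold higher number from compound 1 to compound 3 (0.42 log units; beyond the scatter), and the furthest is compound 2, a 2.9-fold higher number from compound 2 to compound 3 (0.47 log units; beyond the scatter). Compound 4 `Cc1ccccc1C(=O)Nc1cccc(-c2oc3cc(-c4ccc(F)cc4)ccc3c(=O)c2O)c1` differs from compound 3 by methyl in place of methoxy on an aromatic carbon. Going by the values given here, no measured pair tests methyl against methoxy at the same place. The two steps that reach compound 3 both concern the 2-methoxyphenyl, and the step of a 1.1-fold lower number from compound 1 to compound 2 (0.05 log units; within the scatter) shows little change from exchanging groups on that ring. For compound 4 the estimated step is therefore a 1.3-fold lower number from compound 3 to compound 4 (0.11 log units; within the scatter), with no direction beyond the scatter expected. Compound 4 is estimated at 11000 nM, between 4000 nM and 30000 nM.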

Compound 4, half-maximal inhibitory concentration: 11900 nM
Compound 4: middle estimate off by 1.1-fold (0.03 log units), on the low side, within the range that was stated.
By their numbers in this assay, from the lowest: compounds 2 and 1 (each within the scatter of the next); then compounds 4 and 3 (each within the scatter of the next).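

In this assay, methyl and methoxy on the aromatic carbon ortho to a large group give nearly the same result, so removing the oxygen changes little: a 1.2-fold lower number from compound 3 to compound 4 (0.07 log units; within the scatter). Compound 4 also stays apart from the two compounds with a 4-substituted ring, with a 2.5-fold higher number from compound 2 to compound 4 (0.39 log units; beyond the scatter) and a 2.2-fold higher number from compound 1 to compound 4 (0.35 log units; beyond the scatter), and among these four compounds none goes against this pattern. No data shown explain this result. Still open, as far as these compounds go, is whether a chlorine, a hydroxyl or an amine at this place would behave like methyl and methoxy.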